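The source may hold more compounds than are shown below. What is called first, only, known or untested is meant among the compounds shown, and "the series" means these compounds.

The series shares one core, carried by compound 1 `CCCCC#Cc1nc(NCc2cccc(Br)c2)c2ncn([C@H]3[C@H](O)[C@H](O)[C@@H]4C[C@@H]43)c2n1` and compound 2 `CCCCC#Cc1nc(NC)c2ncn([C@H]3[C@H](O)[C@H](O)[C@@H]4C[C@@H]43)c2n1`. In an assay on CHO cells for displacement of a labelled ligand from adenosine receptor A1 (Homo sapiens), read by scintillation counting, with a stated time of 60 min, tested at 10 uM (on this read-out lower numbers stand for less inhibition and higher numbers for more inhibition at the one concentration tested (going by the name of the read-out)), compound 1 gives 38%, and in this assay compound 2 gives 14%. Within the data shown here, the single measured step is a number 24 percentage points lower from compound 1 to compound 2 (beyond the scatter). Among the measured compounds shown here, compound 2 thus stands lowest of the two numbers, with compound 1 its only neighbour, higher by that step.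

Compound 3 `CCCCC#Cc1nc(N)c2ncn([C@H]3[C@H](O)[C@H](O)[C@@H]4C[C@@H]43)c2n1` is the next member; it differs from compound 2 by hydrogen in place of methyl on a nitrogen on an aromatic ring. For the measured compounds named here, the only step that bears on this is a number 24 percentage points lower from compound 1 to compound 2 (beyond the scatter), which also trimmed the substituent on the nitrogen on an aromatic ring, but removed a far larger group. Removing the remaining methyl is a much smaller change, so for this assay no step beyond the scatter is expected, at most a slight drop. Compound 3 is expected to give 10% in this assay, within 0% to 24%, meaning an expected step of a number 4 percentage points lower from compound 2 to compound 3 (within the scatter).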

Compound 3, a percentage reported as inhibition, at one concentration (the size of the read-out at that concentration, not a potency): 29%
The estimate for compound 3 lay 19 percentage points below the measured number; measured number above the stated range.
By their numbers in this assay, from the lowest: compound 2; then compounds 3 and 1 (each within the scatter of the next).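

In this assay the change from methylamino to amino is not silent: the step is a number 15 percentage points higher from compound 2 to compound 3 (beyond the scatter), so even this small change on the nitrogen on an aromatic ring moves the read-out. Taking off the whole substituent gives a number 9 percentage points lower from compound 1 to compound 3 (within the scatter), so across these three compounds the read-out does not follow the size of the group on this nitrogen: compound 2 stands apart, while compound 1 and compound 3 cannot be told apart. Nothing available accounts for this low number with methyl.

Still open, on these data alone, is whether the low number belongs to methyl alone or extends to ethyl, propyl or longer alkyl chains on this nitrogen. Also open, as far as these compounds go, is how an unsubstituted benzyl group would compare with the 3-bromobenzyl of compound 1.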